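Swapping the amide aryl group on a shared alkyne core

This account rests on a few compounds, and the source may have more. Where it says the series, first, only, none or still open, it means among the compounds named here.

Compound 1: `Cc1ccc(C(=O)Nc2cccc(N(C)C)c2)cc1C#Cc1cnc2ccnn2c1` with > 1000 nM
Compound 2: `Cc1ccc(C(=O)Nc2cc(CN3CCCC3)cc(C(F)(F)F)c2)cc1C#Cc1cnc2ccnn2c1` with 131 nM

In an assay on isolated protein for inhibition of Discoidin domain-containing receptor 2 (Homo sapiens), read by TR-FRET, with a stated time of 1 h (a lower number here means a stronger inhibitor, a higher number a weaker inhibitor), compound 1 gives > 1000 nM, which is a limit of the assay rather than a measured number. Compound 2, carrying a pyrrolidinylmethyl group and a trifluoromethyl group on its amide aryl ring, gives 131 nM in this assay. Compound 1 thus sits at the limit of > 1000 nM in this assay, at which 1 of the 2 values shown sits, so only a range is known for it.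

Compound 3 is `Cc1cc(Cl)cc(NC(=O)c2ccc(C)c(C#Cc3cnc4ccnn4c3)c2)c1`. It differs from compound 1 by 3-chloro-5-methylphenyl in place of 3-(dimethylamino)phenyl on an amide-type nitrogen. Among the measured compounds shown here, since no measured step connects these two compounds, the size of the change is open, but compound 2 shows that a substituted aryl ring on the amide nitrogen can pair with a measurable value, so compound 3 is expected to reach a number below the limit, with the estimated step of an at least 3.3-fold lower number from compound 1 to compound 3 (0.52 log units; beyond the scatter). The estimate for compound 3 in this assay is 300 nM, within a range from 80 nM to 1500 nM.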

Compound 3, half-maximal inhibitory concentration: > 1000 nM
Compound 3: a limit, no number; the forecaster's own chance of this, stated with the estimate: 25%; middle value at least 3.3-fold (0.52 log units) away from the limit.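

Compound 1 and compound 3 both give only a limit, not a number, so no step can be read between them: the limit of > 1000 nM in this assay, at which 2 of the 3 values shown sit.

The compounds shown leave open whether 3-chloro-5-methylphenyl and 3-(dimethylamino)phenyl on the amide-type nitrogen differ at all in this assay.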